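A few compounds are considered here, and "the series" means these few. Any claim that something is new, unique, unknown or untested is made for them only; others in the source may bear on it.

Working notes on the series. Compound 1 `O=c1[nH]c(=O)n(COC(CO)CO)cc1O` is measured in a functional assay on MCF7 cells (Homo sapiens) for inhibition, read by MTT assay, with a stated time of 72 h (on this read-out higher numbers stand for weaker inhibition and lower numbers for stronger inhibition), only as a limit, > 100000 nM, so no number is known for it. Compound 3 `Cn1cc(CO)c(N)nc1=O` also gives only a limit, > 100000 nM. Compound 2 `O=C(CCl)Nc1c[nH]c(=O)[nH]c1=O` gives 15000 nM in this assay. Compound 1 thus stands at the limit of > 100000 nM in this assay, at which 2 of the 3 values shown sit. Compound 4 `O=C(CCl)Nc1cn(COC(CO)CO)c(=O)[nH]c1=O` is not yet measured; it differs from compound 1 by ((chloromethyl)carbonyl)amino in place of hydroxy on an aromatic carbon. For the measured compounds named here, no step between measured compounds is known here, so the size of this change rests on expectation alone. Compound 2 carries the same ((chloromethyl)carbonyl)amino group and gives 15000 nM. On that basis an at least 5.0-fold lower number from compound 1 to compound 4 (0.69 log units; beyond the scatter) is expected, a move toward stronger inhibition. Compound 4 is estimated at 20000 nM, with a range from 5000 nM to 100000 nM.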

Compound 4, half-maximal inhibitory concentration: 32000 nM
Estimate against measurement, compound 4: 1.6-fold (0.20 log units) below; the measured number falls inside the stated range.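

For the compounds shown here, on this aromatic carbon, ((chloromethyl)carbonyl)amino in place of hydroxy gives an at least 3.1-fold lower number from compound 1 to compound 4 (0.49 log units; beyond the scatter) in this assay, the first step that can be read at this position. The change therefore yields a measured number on the core of compound 1, which alone offers only a limit. The true size of the step remains unknown, and the printed figure is only its lower bound: the limit of > 100000 nM in this assay, at which 2 of the 4 values shown sit.

The compounds shown leave open whether the chlorine contributes to this step. An acetylamino group or a plain amine on the same carbon would address that question.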